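This account rests on a few compounds, and the source may have more. Where it says the series, first, only, none or still open, it means among the compounds named here.

Three related compounds have been measured in a functional assay on MGC-803 cells (Homo sapiens) for inhibition, read by MTT assay, with a stated time of 48 h; a lower number here means a stronger inhibitor, a higher number a weaker inhibitor. Compound 1 `COc1ccc(CNc2cc(OC)c(OC)c(OC)c2)cc1[N+](=O)[O-]` gives 19400 nM, and compound 2 `COc1ccc(CN(C(=O)C(C)Br)c2cc(OC)c(OC)c(OC)c2)cc1O` gives 120 nM. Compound 3 `COc1cc(NCc2ccc(Br)cc2)cc(OC)c1OC` returns only a limit of this assay, > 80000 nM. Of the two actual numbers, compound 2 holds the lower, and its distance from compound 1 lies beyond the scatter.

The step followed here leads from compound 2 to compound 4 `COc1ccc(CN(C(=O)CO)c2cc(OC)c(OC)c(OC)c2)cc1O`, which has not yet been measured in this assay. The difference between the two structures is hydroxymethyl in place of 1-bromoethyl on a carbonyl carbon. In words, hydroxymethyl stands in place of 1-bromoethyl on a carbonyl carbon, whose other neighbour is an amide-type nitrogen.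

Within the data shown here, no measured pair shows this change directly, so the expectation rests on limited ground. Among the measured compounds shown here, compound 2, at 120 nM, is the only measured compound with this carbonyl on the nitrogen, and it offers no comparison for a different group in that place. A moderate move towards a weaker inhibitor, beyond the scatter, seems the most likely outcome. The estimated step is a 5.0-fold higher number from compound 2 to compound 4 (0.70 log units; beyond the scatter). For compound 4 the estimated value is 600 nM, with an expected range from 90 nM to 4000 nM.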

Compound 4, half-maximal inhibitory concentration: 160 nM
Beside the measured number, compound 4's estimate is 3.8-fold (0.57 log units) above it; low and high end bracket the measured number.
By their numbers in this assay, from the lowest: compounds 2 and 4 (each within the scatter of the next); then compound 1. At a limit, above all of these: compound 3.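

In this assay, replacing 1-bromoethyl with hydroxymethyl on the carbonyl carbon, whose other neighbour is an amide-type nitrogen, gives a 1.3-fold higher number from compound 2 to compound 4 (0.12 log units; within the scatter), so the activity seen in compound 2 at this position does not depend on 1-bromoethyl or its bromine. The change is not a small one in what is counted: the bromine leaves, and hydroxymethyl brings one hydrogen-bond donor and one hydrogen-bond acceptor where 1-bromoethyl has neither, yet compound 2 and compound 4 remain within the scatter of each other. Nothing measured here explains why these two values stay so close.

On these data alone, a single step cannot show how much variation this position accepts, so it remains open whether a simple methyl, an aminomethyl group, a carboxylic acid or a longer chain on this carbonyl carbon would stay with compound 2 and compound 4 or move away from them. As far as these compounds go, compound 1 and compound 3 differ from these two in more than one place, so the contribution of the carbonyl group on the nitrogen also remains open.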